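The source may report more compounds than this note shows. Statements on the series, on what has been measured and on what is new or still open speak of the compounds shown alone.

Three compounds have so far been measured in an assay on HEK293 cells for displacement of a labelled ligand from Neuronal acetylcholine receptor; alpha3/beta4 (Homo sapiens); a lower number here means a stronger inhibitor, a higher number a weaker inhibitor:

Compound 1, `Clc1cccc(Nc2ccc(N3CC4CC(C3)N4)cn2)c1`, gives 4.8 nM.
Compound 2, `Fc1ccc(Nc2cncc(N3CC4CC(C3)N4)c2)cc1`, gives 1.25 nM.
Compound 3, `Clc1cccc(Nc2cncc(N3CC4CC(C3)N4)c2)c1`, gives 293 nM.

Compounds 2 and 3 share one core and differ in a single place: 4-fluorophenyl in place of 3-chlorophenyl on a nitrogen on an aromatic ring. That one swap gave a 230-fold lower number from compound 3 to compound 2 (2.37 log units; beyond the scatter), the largest gap among the measured compounds. Compound 1 carries the same 3-chlorophenyl group as compound 3 but on a core built from the same atoms joined differently; the difference between the two cores is not broken down here. Even so, the two values show that compound 1 sits at a far lower number than compound 3: compound 1 gives 4.8 nM, whereas compound 3 gives 293 nM.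

Compound 4, `Fc1ccc(Nc2ccc(N3CC4CC(C3)N4)cn2)cc1`, has not yet been measured. It is made from compound 1 by the same change that turned compound 3 into compound 2: 4-fluorophenyl in place of 3-chlorophenyl on a nitrogen on an aromatic ring, in the same place. On the core of compound 3 this change made a very large step. On the core of compound 1 a smaller step is expected, because compound 1 already gives 4.8 nM and compound 2, which carries the same 4-fluorophenyl group, gives 1.25 nM, leaving less room to fall. The expected step is a 4.8-fold lower number from compound 1 to compound 4 (0.68 log units; beyond the scatter). Compound 4 is therefore estimated at 1 nM in this assay, most likely between 0.2 nM and 5 nM.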

Compound 4, inhibition constant: 13 nM
Estimate against measurement, compound 4: 13-fold (1.11 log units) below; measured number outside the range, above it.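

On the core of compound 1, putting 4-fluorophenyl in place of 3-chlorophenyl gives a 2.7-fold higher number from compound 1 to compound 4 (0.43 log units; beyond the scatter) in this assay, so the same swap that brought a very large fall on the other core brings a modest rise here, and the two results differ in both direction and size: the same change on two cores in this assay, a 230-fold lower number (2.37 log units; beyond the scatter) from compound 3 to compound 2 and a 2.7-fold higher number (0.43 log units; beyond the scatter) from compound 1 to compound 4, 630-fold (2.80 log units) apart, beyond the scatter of two such steps

In this series, then, the step measured for this change on one core cannot simply be carried over to the other, and neither its size nor its direction survived the move between these two cores. Among the compounds shown here, this rests on only two matched pairs, however, so it shows that the change depends on the core in these compounds, but it does not show why, nor how the change would behave on any further core.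

The swap alters the halogen and its place on the phenyl ring together, so the compounds shown leave open which of the two matters on each core. A plain phenyl group, carrying neither chlorine nor fluorine, or a methoxy group on that ring would be needed on both cores to tell how far the difference between the cores extends beyond this single pair of groups.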